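Swapping a chlorobenzyl for a cyclopropyl on the amine

The source may report more compounds than this note shows. Statements on the series, on what has been measured and on what is new or still open speak of the compounds shown alone.

Two compounds share a core and differ only in the group carried on the amine nitrogen. Compound 1 `COc1cc(Oc2cccc(Nc3ccccc3)c2)cc(OC)c1CNCc1ccc(Br)cc1` gives 11200 nM in a functional assay on SW-620 cells (Homo sapiens) for inhibition, read by MTT assay, with a stated time of 72 h; on this read-out lower numbers stand for stronger inhibition and higher numbers for weaker inhibition. Compound 2 `COc1cc(Oc2cccc(Nc3ccccc3)c2)cc(OC)c1CNCc1ccc(Cl)cc1` gives 6340 nM in this assay. The step of a 1.8-fold lower number from compound 1 to compound 2 (0.25 log units; within the scatter) is within the scatter, so compound 2 has the lower of the two numbers without standing apart from compound 1.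

Compound 3 `COc1cc(Oc2cccc(Nc3ccccc3)c2)cc(OC)c1CNC1CC1` has not been measured. It differs from compound 2 by cyclopropyl in place of 4-chlorobenzyl on an amine nitrogen. Among the measured compounds shown here, the only measured step, from compound 1 to compound 2, concerns the halogen on the 4-chlorobenzyl group and says nothing about removing that group entirely in favour of a cyclopropyl, so no measured step bears directly on this change. Without such guidance, the expectation for compound 3 is a number close to that of compound 2, with a wide range on either side; the step expected is a 1.6-fold higher number from compound 2 to compound 3 (0.20 log units; within the scatter). Compound 3 is therefore estimated at 10000 nM in this assay, between 2500 nM and 40000 nM.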

Compound 3, half-maximal inhibitory concentration: > 20000 nM
Compound 3: a limit, no number (the forecaster's own chance of this, stated with the estimate: 10%); middle value at least 2.0-fold (0.30 log units) away from the limit.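

In this assay compound 3 gives no exact number, only a limit of the assay: the limit of > 20000 nM in this assay, at which 1 of the 3 values shown sits.

The change on the amine nitrogen, cyclopropyl in place of 4-chlorobenzyl, gives an at least 3.1-fold higher number from compound 2 to compound 3 (0.49 log units; beyond the scatter), so this position can respond to a change of group in a way that the swap of one halogen for another did not show. Cyclopropyl in place of 4-bromobenzyl gives an at least 1.7-fold higher number from compound 1 to compound 3 (0.25 log units; that floor lies within the scatter), so on its own this second comparison does not establish a real loss, and a limit cannot show how large either step truly is.

The two benzyl groups and cyclopropyl differ both in ring type and in size, so these compounds cannot show whether the six-membered aromatic ring, the halogen on it or the overall size of the group matters most. A plain benzyl, a phenethyl with its longer chain or a small open chain such as ethyl on the same nitrogen would each test a different part of that question.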